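The compounds below may be only part of what the source reports. "The series", "measured", "known", "first", "only" and "open" are said of these compounds alone.

Of the compounds shown here, three of a shared core have been tested in an ADME assay on HepG2 2.2.15 cells (Homo sapiens) for cytotoxicity, read by MTT assay, with stated times of 48 h and 9 days; on this read-out higher numbers stand for lower toxicity in this test and lower numbers for higher toxicity in this test. Compound 1 `COc1ccc2c(=O)c(/C=C/C(=O)NCc3cccc(F)c3)coc2c1` gives 475000 nM in this assay. Compound 2 `Cc1ccccc1NC(=O)/C=C/c1coc2cc(O)ccc2c1=O` gives 374000 nM, and compound 3 `Cc1ccc(CNC(=O)/C=C/c2coc3cc(O)ccc3c2=O)cc1` gives 501000 nM. On these numbers compound 1 stands second highest of the three, nearest to compound 3 and furthest from compound 2, and both gaps lie within the scatter, so the three compounds cannot be told apart in this assay.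

Going by the values given here, the one step measured between two of them, a 1.3-fold higher number from compound 2 to compound 3 (0.13 log units; within the scatter), changes the group on the amide nitrogen and leaves the read-out essentially where it was.

Compound 4 `COc1ccc2c(=O)c(/C=C/C(=O)NCc3ccc(F)cc3F)coc2c1` differs from compound 1 in one place: 2,4-difluorophenyl in place of 3-fluorophenyl on a saturated chain carbon bound to an amide-type nitrogen. Among the compounds with values here, no measured step touches the fluorine pattern of this ring, so the only guide is that the single change at the amide nitrogen, from compound 2 to compound 3, stayed within the scatter. On that basis compound 4 is expected to remain close to compound 1, with the step of no change at the digits printed from compound 1 to compound 4 (within the scatter) expected to be within the scatter, in no particular direction. The estimate for compound 4 in this assay is 475000 nM, with a range from 240000 nM to 950000 nM.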

Compound 4, half-maximal cytotoxic concentration: 79300 nM
The estimate for compound 4 lay 6.0-fold (0.78 log units) above the measured number; measured number outside the range, below it.
By their numbers in this assay, from the lowest: compound 4; then compounds 2, 1 and 3 (each within the scatter of the next).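

In this assay, the change from 3-fluorophenyl to 2,4-difluorophenyl on a saturated chain carbon bound to an amide-type nitrogen gives a 6.0-fold lower number from compound 1 to compound 4 (0.78 log units; beyond the scatter), which here means higher toxicity in this test. This is the first step beyond the scatter among the compounds shown, so this ring is a place where the read-out can move, and an added fluorine on it is enough to move it. The earlier step on an amide-type nitrogen, a 1.3-fold higher number from compound 2 to compound 3 (0.13 log units; within the scatter), had shown no such movement, although that step exchanged 2-methylphenyl for 4-methylbenzyl and did not touch the fluorine pattern of this ring.

The compounds shown leave open whether the lower number belongs to the 2,4-difluorophenyl group as a whole or to one of its fluorines alone, whether it would carry over to another ring substituent such as chlorine, trifluoromethyl or a carboxylic acid, and whether it would persist with the hydroxyl-bearing core of compound 3. Nothing measured here bears on why this change lowers the number.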